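The source may hold more compounds than are shown below. What is called first, only, known or untested is meant among the compounds shown, and "the series" means these compounds.

Measured compounds:

- compound 1, `C#CCN(CCCOc1ccc2ccc(=O)oc2c1)Cc1ccc(C(C)C)cc1`: 77400 nM
- compound 2, `C#CCN(CCCCOc1ccc2ccc(=O)oc2c1)Cc1ccc(C)cc1`: 94500 nM
- compound 3, `C#CCN(CCCCOc1ccc2ccc(=O)oc2c1)Cc1ccccc1`: 89400 nM

All three were tested in an ADME assay on isolated protein for inhibition of Amine oxidase [flavin-containing] A (Homo sapiens), read by fluorescence and Amplex Red, with stated times of 15 min and 20 min; on this read-out lower numbers stand for stronger inhibition and higher numbers for weaker inhibition. Compound 1 gives the lowest of the three numbers, but its gaps to compound 3 and to compound 2 both fall within the scatter of repeated measurements, so the three compounds cannot be told apart on these data. Among the compounds with values here, the one single-point step among them, a 1.1-fold lower number from compound 2 to compound 3 (0.02 log units; within the scatter), is likewise within the scatter.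

Compound 4, `C#CCN(C)CCCOc1ccc2ccc(=O)oc2c1`, has not yet been measured in this assay. It differs from compound 1 in one place: hydrogen in place of 4-isopropylphenyl on a saturated chain carbon bound to an amine nitrogen. Within the data shown here, no measured step bears directly on this change; the only step available, from compound 2 to compound 3, concerns a methyl on an aromatic carbon, not the loss of a whole 4-isopropylphenyl group from the saturated chain carbon. The expectation for compound 4 is therefore uncertain, with a step of a 1.9-fold higher number from compound 1 to compound 4 (0.29 log units; within the scatter) toward a higher number, meaning weaker inhibition. The estimated value for compound 4 in this assay is 150000 nM, with a range from 40000 nM to 600000 nM.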

Compound 4, half-maximal inhibitory concentration: 36900 nM
Beside the measured number, compound 4's estimate is 4.1-fold (0.61 log units) above it; measured number below the stated range.
By their numbers in this assay, from the lowest: compound 4; then compounds 1, 3 and 2 (each within the scatter of the next).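

In this assay, within the data shown here, hydrogen in place of 4-isopropylphenyl on a saturated chain carbon bound to an amine nitrogen gives a 2.1-fold lower number from compound 1 to compound 4 (0.32 log units; beyond the scatter), the first step here that lies beyond the scatter. Inhibition at this position therefore does not depend on the aromatic ring: the whole group can leave, and the number drops modestly rather than rises. No measurement available here explains why the number falls when this group is removed.

The compounds shown leave open whether a group of intermediate size on this carbon, such as an ethyl or a cyclopropyl, would lower the number further or raise it. They also leave open whether the same removal would give a step of similar size in compound 3, whose chain to the shared core is longer.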